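Urea-linked anilines on a chloropyrazine core: varying the aryl group

The source may hold more compounds than are shown below. What is called first, only, known or untested is meant among the compounds shown, and "the series" means these compounds.

Compound 1 `COc1ccccc1NC(=O)Nc1cccc(CNc2nccnc2Cl)c1`: 12200 nM
Compound 2 `O=C(Nc1cccc(Cl)c1)Nc1cccc(CNc2nccnc2Cl)c1`: 5330 nM

In a functional assay on MGC-803 cells (Homo sapiens) for antiproliferative activity, read by MTT assay, with a stated time of 48 h (on this read-out higher numbers stand for weaker inhibition and lower numbers for stronger inhibition), compound 2 gives the lowest of the two numbers; compound 1 stands a 2.3-fold lower number from compound 1 to compound 2 (0.36 log units; beyond the scatter) behind it. Compound 3 `O=C(Nc1cccc(CNc2nccnc2Cl)c1)Nc1ccccc1F` differs from compound 2 by 2-fluorophenyl in place of 3-chlorophenyl on an amide-type nitrogen. Going by the values given here, the only measured step, a 2.3-fold lower number from compound 1 to compound 2 (0.36 log units; beyond the scatter), also changed this aryl group and was modest, so the same size of movement is expected here, without a secure direction. Compound 3 is therefore estimated at 8000 nM, within 4000 nM to 16000 nM, a step of a 1.5-fold higher number from compound 2 to compound 3 (0.18 log units; within the scatter) that may fall inside the scatter.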

Compound 3, half-maximal inhibitory concentration: 6440 nM
For compound 3 the middle estimate is 1.2-fold (0.09 log units) above the measured one, and the stated range covers the measured number.
By their numbers in this assay, from the lowest: compounds 2, 3 and 1 (each within the scatter of the next, the first and the last beyond it).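

The 2-fluorophenyl and 3-chlorophenyl groups on the amide-type nitrogen cannot be told apart, with a 1.2-fold higher number from compound 2 to compound 3 (0.08 log units; within the scatter) lying within the scatter. Fluoro in place of methoxy on an aromatic carbon gives a 1.9-fold lower number from compound 1 to compound 3 (0.28 log units; within the scatter), also within the scatter, so this exchange, unlike the earlier step to compound 2, is not separated from compound 1. No available evidence bears on these results. The compounds shown leave open whether an aryl group carrying an amine or a carboxylic acid would shift the number beyond the scatter.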